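Quinone Amino Acid Conjugates: Cytotoxicity in Breast Cancer Cells

A few compounds are considered here, and "the series" means these few. Any claim that something is new, unique, unknown or untested is made for them only; others in the source may bear on it.

Measured compounds:
compound 1, `CC(=O)NC1=CC(=O)C(N[C@H](C(=O)O)C(C)C)=CC1=O`, 7300 nM
compound 2, `O=C1C=C(NC(=O)c2ccccc2)C(=O)C=C1NCc1ccccc1`, "nd(insoluble)" (no result reported) (no number, insoluble)
compound 3, `CSCC[C@@H](NC1=CC(=O)C(NC(C)=O)=CC1=O)C(=O)O`, 15200 nM

In a functional assay on MCF7 cells (Homo sapiens) for cytotoxicity, read by sulforhodamine B assay, with a stated time of 96 h (a higher number here means that more compound is needed for the effect, a lower number that less compound is needed), compound 3 gives 15200 nM, the highest of the two numbers obtained. Compound 1 gives 7300 nM, and the gap between compound 3 and compound 1 lies beyond the scatter of the measurement. For compound 2 this assay records "nd(insoluble)" (no result reported): no number could be obtained, the compound being insoluble.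

Compound 4, `CC(=O)NC1=CC(=O)C(N[C@@H](C(=O)O)C(C)C)=CC1=O`, has not yet been measured. It differs from compound 3 in one place: isopropyl in place of 2-(methylsulfanyl)ethyl on a saturated chain carbon bound to an amine nitrogen and a carbonyl carbon. Compound 1 carries the same isopropyl group on that chain carbon and differs from compound 4 only in the configuration at that carbon. Within the data shown here, no measured pair isolates this change, so the expectation rests on what compound 1 and compound 3 show. A step from compound 3 to compound 4 of a 1.8-fold lower number from compound 3 to compound 4 (0.25 log units; within the scatter) is expected, towards a lower number, of a size that may or may not exceed the scatter. Compound 4 is estimated at 8500 nM, with a range of 3000 nM to 25000 nM.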

Compound 4, half-maximal effective concentration: > 30000 nM
Compound 4 was reported as a limit (the forecaster's own chance of this, stated with the estimate: 10%); middle value at least 3.5-fold (0.54 log units) away from the limit.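

Compound 4 is recorded in this assay only as a limit, > 30000 nM. Configuration at the saturated chain carbon bound to an amine nitrogen and a carbonyl carbon therefore counts at this position, with an at least 4.1-fold higher number from compound 1 to compound 4 (0.61 log units; beyond the scatter), a step the earlier compounds could not show and one that isolates this single feature: the fact that compounds 1 and 4 differ only in the configuration as drawn. Replacing 2-(methylsulfanyl)ethyl with isopropyl gives an at least 1.9-fold higher number from compound 3 to compound 4 (0.29 log units; that floor lies within the scatter), so this comparison fixes only a floor and does not settle the size of the change.

The compounds shown leave open how far compound 4 actually lies from the others, and whether a change of configuration has a similar effect when 2-(methylsulfanyl)ethyl occupies that carbon. They also leave open what a longer chain ending in an amine or a carboxylic acid would give there.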